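A few compounds are considered here, and "the series" means these few. Any claim that something is new, unique, unknown or untested is made for them only; others in the source may bear on it.

Compound 1 `CCc1cc(C(C)=O)c(O)cc1OCCCCC#N` and compound 2 `CCCc1cc(C(C)=O)c(O)cc1OCCCCC#N` share one core, while compound 3 `C=CCc1cc(C(C)=O)c(O)cc1OCCCCCC` and the as yet unmeasured compound 4 `C=CCc1cc(C(C)=O)c(O)cc1OCCCCCCC` share another; the difference between the two cores is not broken down here. In an assay on isolated protein for inhibition of leukotriene B4 receptor 1 (Homo sapiens), tested at 10 uM (a higher number here means more inhibition at the concentration tested (going by the name of the read-out), a lower number less inhibition), compound 1 gives 92% and compound 2 gives 84%, so the change methyl in place of hydrogen on a saturated chain carbon, two bonds along the chain from an aromatic carbon made a step of a number 8 percentage points lower from compound 1 to compound 2 (within the scatter). Compound 3 gives 50% in this assay, the lowest of the three numbers and beyond the scatter from both compound 1 and compound 2. The change from compound 3 to compound 4 is methyl in place of hydrogen on a saturated chain carbon, six bonds along the chain from an oxygen on an aromatic ring. It is the same kind of change as from compound 1 to compound 2, but the place differs: there the carbon was two bonds along the chain from an aromatic carbon, here it is six bonds along the chain from an oxygen on an aromatic ring. Because a number 8 percentage points lower from compound 1 to compound 2 (within the scatter) stayed within the scatter, a step of a number 5 percentage points lower from compound 3 to compound 4 (within the scatter) is expected for compound 4 in this assay. Compound 4 is therefore estimated at 45%, between 25% and 65%.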

Compound 4, a percentage reported as inhibition, at one concentration (the size of the read-out at that concentration, not a potency): 31%
The estimate for compound 4 lay 14 percentage points above the measured number, within the range that was stated.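

In this assay the methyl in place of hydrogen made a number 19 percentage points lower from compound 3 to compound 4 (beyond the scatter) on the core of compound 3, a modest step when read alone. Set beside the earlier step, the two lie no further apart than the scatter of two such steps allows: the same change on two cores in this assay, a number 8 percentage points lower (within the scatter) from compound 1 to compound 2 and a number 19 percentage points lower (beyond the scatter) from compound 3 to compound 4, 11 percentage points apart, within the scatter of two such steps. Within the data shown here, this shows that the two steps can be read as compatible, but it does not show that the change carries over from one core to the other with the same size, since there are only two steps, the change sits at a different place on each core, and one step lies within the scatter while the other lies beyond it.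

The compounds shown leave open how a longer chain in place of the one on compound 4 would read in this assay and whether the trend would continue. They also leave open what a carboxylic acid or an amine at the end of that chain would do on this core.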